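Swapping the fluorobenzylamine for a tetrahydroisoquinoline

This account rests on a few compounds, and the source may have more. Where it says the series, first, only, none or still open, it means among the compounds named here.

Compound 1 `CN(Cc1cccc(F)c1)C(=O)CCCNC(=O)c1ccc(S(C)(=O)=O)c([N+](=O)[O-])c1` gives in an assay on isolated protein for inhibition of thyroid hormone receptor beta (Homo sapiens), read by fluorescence polarization; on this read-out higher numbers stand for weaker inhibition and lower numbers for stronger inhibition > 60000 nM, which is a limit of the assay.
Compound 2 `CN(Cc1cccc(F)c1)C(=O)CN(C)C(=O)c1ccc(S(C)(=O)=O)c([N+](=O)[O-])c1` gives in this assay > 60000 nM, which is a limit.
Compound 3 `CN(Cc1cccc(F)c1)C(=O)CNC(=O)c1ccc(S(C)(=O)=O)c([N+](=O)[O-])c1` gives in this assay > 60000 nM, which is a limit.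

Compound 2 therefore stands at the limit, as do the other two values shown, (the limit of > 60000 nM in this assay, at which 3 of the 3 values shown sit). For the measured compounds named here, the single measured step, a step that the two limits leave unreadable from compound 2 to compound 3, is unreadable, since both ends of it are limits. Compound 4 `CN(CC(=O)N1CCc2ccccc2C1)C(=O)c1ccc(S(C)(=O)=O)c([N+](=O)[O-])c1` differs from compound 2 by 1,2,3,4-tetrahydroisoquinolin-2-yl in place of (3-fluorobenzyl)(methyl)amino on a carbonyl carbon. Going by the values given here, no measured step bears on this change, and the three limits offer no footing for expecting a readable number. Compound 4 is expected to give about 80000 nM (range 20000 nM to 300000 nM), an expected step that the limit leaves unreadable from compound 2 to compound 4 that would most likely again be reported only as a limit.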

Compound 4, half-maximal inhibitory concentration: > 60000 nM
Compound 4: a limit, no number; the forecaster's own chance of this, stated with the estimate: 85%; the middle value does not contradict the limit.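

For the compounds shown here, compound 2 and compound 4 both stand at a limit of the assay, so no step between them can be read. The compounds shown leave open whether any change gives a readable number in this assay at all, since all of them sit at the same point: the limit of > 60000 nM in this assay, at which 4 of the 4 values shown sit.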